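The compounds below may be only part of what the source reports. "The series", "measured", "known", "first", "only" and "open" are said of these compounds alone.

Three compounds share one core and differ only in the group on one aromatic carbon. Compound 1 `Cc1cc(-c2ccc(F)cc2)c(S(C)(=O)=O)cc1C(=O)N=C(N)N` gives 36 nM in a functional assay for inhibition of sodium/hydrogen exchanger (Oryctolagus cuniculus); a higher number here means a weaker inhibitor, a lower number a stronger inhibitor. Compound 2 `Cc1cc(OC2CCCC2)c(S(C)(=O)=O)cc1C(=O)N=C(N)N` gives 27 nM, and compound 3 `Cc1cc(Oc2ccccc2)c(S(C)(=O)=O)cc1C(=O)N=C(N)N` gives 10 nM. Compound 3 thus has the lowest number of the three: the step of a 3.6-fold lower number from compound 1 to compound 3 (0.56 log units; beyond the scatter) and the step of a 2.7-fold lower number from compound 2 to compound 3 (0.43 log units; beyond the scatter) are both beyond the scatter, while the step of a 1.3-fold lower number from compound 1 to compound 2 (0.12 log units; within the scatter) is not.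

Compound 4 `Cc1cc(-n2ccnc2C)c(S(C)(=O)=O)cc1C(=O)N=C(N)N` has not yet been measured. It differs from compound 3 in one place: 2-methyl-1H-imidazol-1-yl in place of phenoxy on an aromatic carbon. Among the compounds with values here, no measured step puts a five-membered aromatic ring with 2 hetero atoms in this place, so the bearing of the earlier steps is indirect. The two steps that reach compound 3 show that the two other groups tried here gave modestly higher numbers, leaving the phenoxy alone at the low end. Since the entering group is again a different kind of ring, a modest rise back toward the numbers of compounds 1 and 2 seems the likelier outcome, though with wide uncertainty. Compound 4 is therefore expected to give about 30 nM in this assay, within a range from 10 nM to 100 nM. That estimate amounts to an expected step of a 3.0-fold higher number from compound 3 to compound 4 (0.48 log units; beyond the scatter).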

Compound 4, half-maximal inhibitory concentration: 29 nM
Beside the measured number, compound 4's estimate is 1.0-fold (0.01 log units) above it, and the stated range covers the measured number.
By their numbers in this assay, from the lowest: compound 3; then compounds 2, 4 and 1 (each within the scatter of the next).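

In this assay, within the data shown here, the 2-methyl-1H-imidazol-1-yl group brings a five-membered aromatic ring with 2 hetero atoms to this aromatic carbon for the first time, and a 2.9-fold higher number from compound 3 to compound 4 (0.46 log units; beyond the scatter) leaves the phenoxy group alone at the low end of the series. The two other new comparisons, a 1.1-fold higher number from compound 2 to compound 4 (0.03 log units; within the scatter) and a 1.2-fold lower number from compound 1 to compound 4 (0.09 log units; within the scatter), are both within the scatter, so the 2-methyl-1H-imidazol-1-yl, cyclopentyloxy and 4-fluorophenyl groups cannot be told apart here, even though they differ clearly in structure. Nothing measured here explains why the phenoxy group stands apart from the other three.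

From the compounds shown here alone, it remains open whether the lower number is special to the plain phenoxy group or extends to close relatives such as 4-fluorophenoxy or a phenylamino group at the same carbon. Also open, going by these compounds, is what the methyl group on the imidazole ring contributes, a question that a plain 1H-imidazol-1-yl group at this position would address directly.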